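Ethyl to isopropyl carbamate on a pyrazolylamino quinazoline core

This account rests on a few compounds, and the source may have more. Where it says the series, first, only, none or still open, it means among the compounds named here.

Measured compounds:
- compound 1, `CC(OC(=O)N1CCN(C(=O)c2nc(Nc3cc(C4CC4)[nH]n3)c3cc(Cl)ccc3n2)C[C@H]1C)OC(=O)C(C)(C)C`: 65.3%
- compound 2, `C[C@@H]1CN(C(=O)c2nc(Nc3cc(C4CC4)[nH]n3)c3cc(Cl)ccc3n2)CCN1C(=O)OCOC(=O)C(C)(C)C`: 60.5%
- compound 3, `CCOC(=O)N1CCN(C(=O)c2nc(Nc3cc(C4CC4)[nH]n3)c3cc(Cl)ccc3n2)C[C@H]1C`: 93.4%

These numbers come from an assay for inhibition of serine/threonine-protein kinase PAK 4 (Homo sapiens), read by FRET and Z'-LYTE, with a stated time of 60 min, tested at 50 uM, in the presence of a further agent that is not named here; a higher number here means a stronger effect of the compound at the concentration tested, a lower number a weaker effect. Compound 3 gives the highest number of the three; the steps of a number 28.1 percentage points higher from compound 1 to compound 3 (beyond the scatter) and a number 32.9 percentage points higher from compound 2 to compound 3 (beyond the scatter) are both beyond the scatter. Compound 3 differs from compound 2 by methyl in place of ((tert-butyl)carbonyl)oxy on a saturated chain carbon bound to an oxygen next to a carbonyl group. Compound 4, `CC(C)OC(=O)N1CCN(C(=O)c2nc(Nc3cc(C4CC4)[nH]n3)c3cc(Cl)ccc3n2)C[C@H]1C`, has not yet been measured in this assay. It differs from compound 3 by methyl in place of hydrogen on a saturated chain carbon bound to an oxygen next to a carbonyl group and a saturated chain carbon. The same kind of change appears between compound 2 and compound 1, (methyl in place of hydrogen on a saturated chain carbon bound to two oxygens next to a carbonyl group), where the step of a number 4.8 percentage points higher from compound 2 to compound 1 (within the scatter) lies within the scatter; there the place is a saturated chain carbon bound to two oxygens next to a carbonyl group, while in compound 4 it is a saturated chain carbon bound to an oxygen next to a carbonyl group and a saturated chain carbon, so the surroundings are not identical. Because a number 4.8 percentage points higher from compound 2 to compound 1 (within the scatter) is within the scatter, the step of a number 5.4 percentage points lower from compound 3 to compound 4 (within the scatter) is expected to be small as well. Compound 4 is therefore estimated at 88%, plausibly between 70% and 99%.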

Compound 4, a percentage reported as inhibition, at one concentration (the size of the read-out at that concentration, not a potency): 91.2%
Compound 4: middle estimate off by 3.2 percentage points, on the low side, and the stated range covers the measured number.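

In this assay, ethyl to isopropyl gives a number 2.2 percentage points lower from compound 3 to compound 4 (within the scatter), and methyl in place of hydrogen also changes little where that carbon is bound to two oxygens: the same change on two cores in this assay, a number 4.8 percentage points higher (within the scatter) from compound 2 to compound 1 and a number 2.2 percentage points lower (within the scatter) from compound 3 to compound 4, 7 percentage points apart, within the scatter of two such steps. Isopropyl in place of (((tert-butyl)carbonyl)oxy)methyl gives a number 30.7 percentage points higher from compound 2 to compound 4 (beyond the scatter), and methyl in place of ((tert-butyl)carbonyl)oxy gives a number 25.9 percentage points higher from compound 1 to compound 4 (beyond the scatter), which agrees with the earlier step of the same kind: the same change on two cores in this assay, a number 32.9 percentage points higher (beyond the scatter) from compound 2 to compound 3 and a number 25.9 percentage points higher (beyond the scatter) from compound 1 to compound 4, 7 percentage points apart, within the scatter of two such steps. Each change is seen only twice, on closely related compounds and at one concentration, so this shows that both changes carried over within these four compounds, but not that they would do so on other cores, nor how potency differs.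

The compounds shown leave open what a longer chain, such as butyl, or an amine would do in place of the isopropyl. They also leave open whether compound 3 and compound 4 would separate at a lower concentration, where the read-out might not lie so close to its top.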